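A few compounds are considered here, and "the series" means these few. Any claim that something is new, unique, unknown or untested is made for them only; others in the source may bear on it.

Compound 1 `CC1CCN(C2CCN(S(=O)(=O)c3cccnc3Cl)CC2)CC1` gives > 10000 nM in an ADME assay on HCT-116 cells (Homo sapiens) for cytotoxicity, read by CellTiter-Glo, with a stated time of 72 h (on this read-out higher numbers stand for weaker inhibition and lower numbers for stronger inhibition), a limit of the assay.
Compound 2 `CC1CCN(C2CCN(S(=O)(=O)c3cccnc3)CC2)CC1` gives > 10000 nM in this assay, also a limit.
Compound 3 `CC1CCN(C2CCN(S(=O)(=O)c3ccccc3-c3ccccc3)CC2)CC1` gives > 5000 nM in this assay, again a limit.

The difference between the core of compound 2 and the core of compound 3 is not broken down here. From compound 2 to compound 1 the change is chloro in place of hydrogen on an aromatic carbon, and the step that the two limits leave unreadable from compound 2 to compound 1 cannot be read, due to the limit of > 10000 nM in this assay, at which 2 of the 3 values shown sit. Compound 4 `CC1CCN(C2CCN(S(=O)(=O)c3ccccc3-c3ccc(Cl)cc3)CC2)CC1`, not yet measured, differs from compound 3 by chloro in place of hydrogen on an aromatic carbon. This is the same kind of change, but the place differs: in compound 1 the chloro sits on a six-membered aromatic ring with 1 nitrogen, next to the ring nitrogen and ortho to a large group, whereas in compound 4 it sits on a six-membered aromatic ring of carbon only, para to a large group. Since compound 3 sits at the limit of > 5000 nM in this assay, at which 1 of the 3 values shown sits, and the earlier step gives no readable size, compound 4 is expected to remain near that limit, with an expected step that the limit leaves unreadable from compound 3 to compound 4. Compound 4 is estimated at 20000 nM, expected between 5000 nM and 100000 nM.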

Compound 4, half-maximal inhibitory concentration: > 5000 nM
Compound 4 was reported as a limit (the forecaster's own chance of this, stated with the estimate: 85%); the middle value does not contradict the limit.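

No new step can be read from compound 3 to compound 4, since both values are limits: the limit of > 5000 nM in this assay, at which 2 of the 4 values shown sit.

The compounds shown leave open whether chloro in place of hydrogen changes the cytotoxicity at all.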